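The source may hold more compounds than are shown below. What is called first, only, known or untested is meant among the compounds shown, and "the series" means these compounds.

Measured so far in an ADME assay on HepG2 cells (Homo sapiens) for cytotoxicity; a lower number here means that less compound is tolerated, a higher number that more compound is tolerated:
Compound 1 `CCOC(=O)CN(C)CC#Cc1cc2ncnc(Nc3ccc(OCc4cccc(F)c4)c(Cl)c3)c2s1`: 26 uM
Compound 2 `CN(C)CC#Cc1cc2ncnc(Nc3ccc(OCc4cccc(F)c4)c(Cl)c3)c2s1`: > 32 uM

The reading for compound 2 is a limit and not a number. Compound 2 thus stands at the limit of > 32 uM in this assay, at which 1 of the 2 values shown sits. Compound 3 `CC(C)CC#Cc1cc2ncnc(Nc3ccc(OCc4cccc(F)c4)c(Cl)c3)c2s1` departs from compound 2 by a single change, (isopropyl in place of dimethylamino on a saturated chain carbon bound to a triple-bonded carbon), on a saturated chain carbon bound to a triple-bonded carbon.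

Within the data shown here, only one measured step bears on this, and only loosely. That step, an at least 1.2-fold higher number from compound 1 to compound 2 (0.09 log units; that floor lies within the scatter), keeps the amine nitrogen and has a floor within the scatter. Among the measured compounds shown here, no measured step replaces dimethylamino, so the data favour no direction, and no change beyond the scatter is expected in this assay. The expected step is an at least 1.0-fold lower number from compound 2 to compound 3 (0.02 log units; that floor lies within the scatter). Compound 3 is estimated at 30 uM, with an expected range of 14 uM to 64 uM.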

Compound 3, half-maximal toxic concentration: > 32 uM
Compound 3: only a limit was reported; the forecaster's own chance of this, stated with the estimate: 45%; middle value at least 1.0-fold (0.02 log units) away from the limit.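

In this assay, compound 3 gives > 32 uM, which is a limit and not a number. Dimethylamino can therefore give way to isopropyl, which holds no nitrogen, and the reading still stands at a limit, while the record shows an at least 1.2-fold higher number from compound 1 to compound 3 (0.09 log units; that floor lies within the scatter). The step between dimethylamino and isopropyl itself cannot be read, because compound 2 and compound 3 both gave limits: the limit of > 32 uM in this assay, at which 2 of the 3 values shown sit.

As far as these compounds go, whether a carboxylic acid, a morpholine or a longer chain on this saturated chain carbon bound to a triple-bonded carbon would give a number rather than a limit stays open. Also open, from the compounds shown here alone, is whether compound 2 and compound 3 differ at all in this assay.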